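The compounds below may be only part of what the source reports. "The series", "measured", "known", "first", "only" and "open" are said of these compounds alone.

Measured in a functional assay on the whole organism for inhibition, with Rattus norvegicus as the target, read by paw edema, with stated times of 1 h and 3 h; a higher number here means that more compound is needed for the effect, a lower number that less compound is needed:
- compound 1 `C/C(=N\OCC(=O)O)c1ccc(Br)cc1`: 27 mg/kg
- compound 2 `C/C(=N\OCC(=O)O)c1ccc(C(F)(F)F)cc1`: 120 mg/kg

Compound 1, at 27 mg/kg, holds the lower of the two numbers, so less of it is needed than of compound 2. Compound 3 `COC(=O)CO/N=C(\C)c1ccc(Br)cc1` keeps the core of compound 1 and differs by methyl in place of hydrogen on an oxygen next to a carbonyl group; this is methyl in place of hydrogen on an oxygen next to a carbonyl group, which turns carboxy to methoxycarbonyl. Among the measured compounds shown here, no measured pair shows this change. For the measured compounds named here, the only measured step, a 4.4-fold higher number from compound 1 to compound 2 (0.65 log units; beyond the scatter), is trifluoromethyl in place of bromo on an aromatic carbon, a different place, so it offers a rough size and no direction. A step no larger than that one is expected, quite possibly none beyond the scatter. The expected step is a 1.1-fold higher number from compound 1 to compound 3 (0.05 log units; within the scatter). For compound 3 the estimate is 30 mg/kg, with an expected range of 10 mg/kg to 90 mg/kg.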

Compound 3, dose for half-maximal effect: 14 mg/kg
Beside the measured number, compound 3's estimate is 2.1-fold (0.33 log units) above it, and the stated range covers the measured number.
By their numbers in this assay, from the lowest: compounds 3 and 1 (each within the scatter of the next); then compound 2.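

Putting methyl in place of hydrogen on an oxygen next to a carbonyl group, which turns carboxy to methoxycarbonyl, gives a 1.9-fold lower number from compound 1 to compound 3 (0.29 log units; within the scatter) in this assay, so the carboxy hydrogen can be exchanged for methyl with no step beyond the scatter. This place therefore behaves differently from the aromatic carbon, where trifluoromethyl in place of bromo gave a 4.4-fold higher number from compound 1 to compound 2 (0.65 log units; beyond the scatter) and moved the number beyond the scatter. No measurement is at hand that would explain this result.

The compounds shown leave open whether methoxycarbonyl would behave the same way alongside trifluoromethyl on the aromatic carbon. They also leave open whether a longer chain on that oxygen, such as ethyl, or an amide in place of the carboxy group would stay within the scatter of compound 1.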